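The compounds below may be only part of what the source reports. "The series", "measured", "known", "first", "only" and "open" are said of these compounds alone.

Measured compounds: compound 1 `COc1ccc(C(=O)/C=C/c2ccc(OCc3cn(Cc4ccccc4Br)nn3)cc2)cc1` with 60% in a functional assay on MCF7 cells (Homo sapiens) for inhibition, read by MTT assay, with a stated time of 48 h, tested at 10 uM; on this read-out lower numbers stand for less inhibition of growth and higher numbers for more inhibition of growth at the one concentration tested; compound 2 `O=C(/C=C/c1ccc(OCc2cn(Cc3ccccc3Br)nn2)cc1)c1ccc([N+](=O)[O-])cc1` with 43% in this assay.

Among the measured compounds shown here, compound 2 stands lowest of the two numbers; the only measured step, a number 17 percentage points lower from compound 1 to compound 2 (beyond the scatter), separates it from compound 1. Compound 3 `O=C(/C=C/c1ccc(OCc2cn(Cc3ccc(F)cc3)nn2)cc1)c1ccc([N+](=O)[O-])cc1` differs from compound 2 by 4-fluorophenyl in place of 2-bromophenyl on a saturated chain carbon bound to an aromatic nitrogen. For the measured compounds named here, no measured step touches this part of the molecule; the one step known concerns the other end. There is therefore no basis for a change beyond the scatter, and compound 3 is expected to give 43% with a range of 28% to 58%, an estimated step of no change at the digits printed from compound 2 to compound 3 (within the scatter).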

Compound 3, percent growth inhibition at one concentration: 38%
Compound 3: the middle estimate sits 5 percentage points above what was measured; the measured number falls inside the stated range.
By their numbers in this assay, from the lowest: compounds 3 and 2 (each within the scatter of the next); then compound 1.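

At the saturated chain carbon bound to an aromatic nitrogen, 4-fluorophenyl in place of 2-bromophenyl gives, in this assay, a number 5 percentage points lower from compound 2 to compound 3 (within the scatter). Among the compounds shown here, this is the first step read at this end of the molecule, and the scatter does not separate the two groups on the nitro-bearing compounds. Nothing measured here accounts for this result.

On these data alone, whether the two groups also stay within the scatter on the methoxy-bearing compound 1 remains open. So does the effect of an amine or a carboxylic acid on this phenyl ring, or of a longer chain at this position.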